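The source may hold more compounds than are shown below. What is called first, only, known or untested is meant among the compounds shown, and "the series" means these compounds.

Measured so far in a functional assay on HL-60 cells (Homo sapiens) for antiproliferative activity, with a stated time of 24 h; on this read-out higher numbers stand for weaker inhibition and lower numbers for stronger inhibition:
Compound 1 `NC(=O)c1c(NC(=O)c2ccccc2Cl)sc2c1CCN(C(=O)Nc1ccccc1Cl)C2` gives 12500 nM.
Compound 2 `Cc1ccccc1NC(=S)N1CCc2c(sc(NC(=O)c3ccccc3Cl)c2C(N)=O)C1` gives 22600 nM.

Compound 2 holds the highest of the two numbers in this assay, but its nearest neighbour is compound 1, and the step of a 1.8-fold higher number from compound 1 to compound 2 (0.26 log units; within the scatter) lies within the usual scatter of repeated measurements, so the two compounds cannot be told apart on these data.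

Compound 3 `CSc1ccccc1NC(=S)N1CCc2c(sc(NC(=O)c3ccccc3Cl)c2C(N)=O)C1` differs from compound 2 in one place only: methylsulfanyl in place of methyl on an aromatic carbon. Among the compounds with values here, the single measured step, from compound 1 to compound 2, exchanged a whole group on the amine nitrogen in the ring and was itself within the scatter. Within the data shown here, it does not touch the spot that changes here, so no measured step speaks directly to a methylsulfanyl in place of a methyl on the aromatic carbon. With no guidance from the numbers, the expectation is a step of no more than the scatter in either direction, a 1.1-fold lower number from compound 2 to compound 3 (0.05 log units; within the scatter). Compound 3 is therefore estimated at 20000 nM in this assay, with a range from 8000 nM to 50000 nM.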

Compound 3, half-maximal inhibitory concentration: 14600 nM
Estimate against measurement, compound 3: 1.4-fold (0.14 log units) above, and the stated range covers the measured number.
By their numbers in this assay, from the lowest: compounds 1, 3 and 2 (each within the scatter of the next).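

In this assay, methylsulfanyl in place of methyl on this aromatic carbon, ortho to a large group, gives a 1.5-fold lower number from compound 2 to compound 3 (0.19 log units; within the scatter) and so leaves the two compounds indistinguishable, even though the entering group adds a sulfur atom and a hydrogen-bond acceptor. The larger exchange of the whole group on the amine nitrogen in the ring gives a 1.2-fold higher number from compound 1 to compound 3 (0.07 log units; within the scatter) and is also too small to separate its two compounds, so all three compounds shown remain within the scatter of one another. None of the available data bears on this result or accounts for it.

Going by these compounds, only methyl and methylsulfanyl can be compared at this aromatic carbon, so it remains open whether a quite different group there, such as an amine or a carboxylic acid, would move the number beyond the scatter. The step between compound 1 and compound 3 also changes the group on the amine nitrogen as a whole, so it cannot show what any single part of that exchange contributes.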